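The source may report more compounds than this note shows. Statements on the series, on what has been measured and on what is new or still open speak of the compounds shown alone.

Of the compounds shown here, two have been measured so far in an assay on isolated protein for inhibition of serine/threonine-protein kinase TNNI3K (Homo sapiens); a lower number here means a stronger inhibitor, a higher number a weaker inhibitor. Compound 1, with the structure `CCNc1cc(Oc2ccc(NC(=O)Nc3cccc(C(F)(F)F)c3)cc2)ncn1`, gives 25 nM in this assay. Compound 2, with the structure `CCc1cc(NC(=O)Nc2cccc(C(F)(F)F)c2)cc(Cl)c1Oc1cc(NC)ncn1`, is known only by a limit: in this assay compound 2 gives <= 10 nM, which is a limit of the assay rather than a measured number (the limit of <= 10 nM in this assay, at which 1 of the 2 values shown sits). Where compound 2 truly stands within that limit is therefore open; all that can be said is that its value is no weaker than the limit itself.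

Compound 3, with the structure `CNc1cc(Oc2c(C)cc(NC(=O)Nc3cccc(C(F)(F)F)c3)cc2Cl)ncn1`, is not yet measured. It differs from compound 2 in a single place: hydrogen in place of methyl on a saturated chain carbon bound to an aromatic carbon. Within the data shown here, no pair of measured compounds shows this change on its own, so there is no measured step to lean on. The change is small, and the expectation is that the step from compound 2 to compound 3 stays within the usual scatter of repeated measurements, a number no lower from compound 2 to compound 3 (the limit leaves the size open), in either direction. On that basis compound 3 is estimated to give about 10 nM in this assay, with a range expected from 3 nM to 30 nM.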

Compound 3, half-maximal inhibitory concentration: 79 nM
Estimate against measurement, compound 3: 7.9-fold (0.90 log units) below; measured number above the stated range.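

Shortening ethyl to methyl, with the change falling on a saturated chain carbon bound to an aromatic carbon, gives an at least 7.9-fold higher number from compound 2 to compound 3 (0.89 log units; beyond the scatter) in this assay. Among these compounds, no earlier pair isolated this place, and the result now shows that the loss of a single carbon here is enough to give a clearly weaker number, with the ethyl compound on the stronger side. That step is only a minimum, and the real gap could be wider, because compound 2 is known only by a limit and not by a measured number: the limit of <= 10 nM in this assay, at which 1 of the 3 values shown sits.

The compounds shown carry only ethyl or methyl at this place, so it remains open whether a longer chain such as propyl, a branched one such as isopropyl, or a small ring such as cyclopropyl would keep, extend or lose the stronger number that ethyl gives. As far as these compounds go, it also remains open whether shortening ethyl to methyl would give a step of similar size on a core that lacks the chlorine carried by compound 2 and compound 3.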